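N-hydroxyindole dicarbonitriles: methoxy for methyl at the aryl

A few compounds are considered here, and "the series" means these few. Any claim that something is new, unique, unknown or untested is made for them only; others in the source may bear on it.

Two measured compounds frame the series. Compound 1 `N#Cc1cc2cc(-c3ccccc3)n(O)c2cc1C#N` gives 6920 nM in an assay on isolated protein for inhibition of Amine oxidase [flavin-containing] A (Homo sapiens), read by fluorescence and spectrophotometry, with a stated time of 20 min; a lower number here means a stronger inhibitor, a higher number a weaker inhibitor. For the measured compounds named here, compound 2 `Cc1ccc(-c2cc3cc(C#N)c(C#N)cc3n2O)cc1` gives 1140 nM in this assay, the lowest of the two numbers; its only neighbour is compound 1, and the step of a 6.1-fold lower number from compound 1 to compound 2 (0.78 log units; beyond the scatter) lies beyond the scatter. Compound 3 `COc1ccc(-c2cc3cc(C#N)c(C#N)cc3n2O)cc1` is not yet measured. It differs from compound 2 by methoxy in place of methyl on an aromatic carbon. Going by the values given here, the single measured step, methyl for hydrogen at the same position, moved the number modestly downward; no step swaps one substituent for another there, so the direction for methoxy rests on that one change alone. A small substituent at this position has already been tolerated, so compound 3 is expected to stay near compound 2, with a step of about a 1.1-fold lower number from compound 2 to compound 3 (0.06 log units; within the scatter) in this assay. Compound 3 is estimated at 1000 nM, within a range of 300 nM to 3500 nM.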

Compound 3, half-maximal inhibitory concentration: 1840 nM
Beside the measured number, compound 3's estimate is 1.8-fold (0.26 log units) below it, within the range that was stated.
By their numbers in this assay, from the lowest: compounds 2 and 3 (each within the scatter of the next); then compound 1.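

In this assay, methoxy in place of methyl on the aromatic carbon para to a large group gives a 1.6-fold higher number from compound 2 to compound 3 (0.21 log units; within the scatter), so this assay does not separate the two substituents here, even though methoxy brings one hydrogen-bond acceptor and methyl none. The step beyond the scatter from hydrogen at this position is no longer tied to methyl alone, since methoxy also gives a 3.8-fold lower number from compound 1 to compound 3 (0.58 log units; beyond the scatter) and so runs in the same direction as a 6.1-fold lower number from compound 1 to compound 2 (0.78 log units; beyond the scatter). No available evidence bears on the reason for these steps.

On these data alone, whether an amine, a carboxylic acid or a longer chain such as butoxy at this position would keep the number near those of compound 2 and compound 3 remains open. The compounds shown also leave open whether a halogen such as chlorine would do the same.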